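A few compounds are considered here, and "the series" means these few. Any claim that something is new, unique, unknown or untested is made for them only; others in the source may bear on it.

In a functional assay on RL cells (Homo sapiens) for cytotoxicity, with a stated time of 48 h (on this read-out lower numbers stand for stronger inhibition and higher numbers for weaker inhibition), compound 1 (`COc1cc(O)c(C(=O)/C=C/c2ccc(F)cc2)c(OC)c1`) gives 5400 nM, compound 2 (`COc1cc(OC)c(C(=O)/C=C/c2ccccc2OC)c(OC)c1`) gives 9000 nM and compound 3 (`COc1cc(OC)c(C(=O)/C=C/c2ccccc2SC)c(OC)c1`) gives 8300 nM. Compound 2 thus stands within the scatter of both other compounds. Compound 4 (`COc1cccc(/C=C/C(=O)c2c(OC)cc(OC)cc2OC)c1`) has not yet been measured, and its difference from compound 2 is this: 3-methoxyphenyl in place of 2-methoxyphenyl on a double-bonded chain carbon bound to a double-bonded chain carbon. The two have the same atoms, joined differently. For the measured compounds named here, only one measured step bears on this change, a 1.1-fold lower number from compound 2 to compound 3 (0.04 log units; within the scatter), and it replaces the methoxy group instead of moving it, so it is only an indirect guide. No shift beyond the scatter is therefore expected in this assay, and the expected change is a 1.1-fold lower number from compound 2 to compound 4 (0.05 log units; within the scatter). For compound 4 the estimated value is 8000 nM, with an expected range of 3500 nM to 18000 nM.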

Compound 4, half-maximal inhibitory concentration: 5900 nM
The estimate for compound 4 lay 1.4-fold (0.13 log units) above the measured number; low and high end bracket the measured number.
By their numbers in this assay, from the lowest: compounds 1, 4, 3 and 2 (each within the scatter of the next).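

Moving the methoxy group, with 3-methoxyphenyl in place of 2-methoxyphenyl, gives a 1.5-fold lower number from compound 2 to compound 4 (0.18 log units; within the scatter) in this assay and so provides the first direct reading of this change at this place. Exchanging 2-(methylsulfanyl)phenyl for 3-methoxyphenyl gives a 1.4-fold lower number from compound 3 to compound 4 (0.15 log units; within the scatter) and likewise shows no shift beyond the scatter. Nothing available explains either small step. Still open, on these data alone, is whether an amine or a carboxylic acid in place of the methoxy group on this ring would move the number beyond the scatter.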